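This account rests on a few compounds, and the source may have more. Where it says the series, first, only, none or still open, it means among the compounds named here.

Measured so far in a functional assay on NCI-H23 cells (Homo sapiens) for inhibition, read by sulforhodamine B assay, with a stated time of 48 h, tested at 10 uM; on this read-out higher numbers stand for more inhibition at the one concentration tested (going by the name of the read-out) and lower numbers for less inhibition:
compound 1 `c1ccc2c(-c3cn4ccnc4c(-c4ccc5ncn(C6CCCCC6)c5c4)n3)cccc2c1` gives 4.32%;
compound 2 `Fc1ccc(-c2cn3ccnc3c(-c3ccc4ncn(C5CCCCC5)c4c3)n2)cc1` gives 2.36%;
compound 3 `Clc1ccc(-c2cn3ccnc3c(-c3ccc4ncn(C5CCCCC5)c4c3)n2)cc1` gives 4.11%.

Compound 3 stands second highest of the three numbers, but its nearest neighbour is compound 1, at a step of a number 0.2 percentage points lower from compound 1 to compound 3 (within the scatter), and its furthest is compound 2, at a number 1.8 percentage points higher from compound 2 to compound 3 (within the scatter), so all three values sit within the scatter of one another and no order among them can be claimed.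

Compound 4 `COc1ccccc1-c1cn2ccnc2c(-c2ccc3ncn(C4CCCCC4)c3c2)n1` differs from compound 3 in one place: 2-methoxyphenyl in place of 4-chlorophenyl on an aromatic carbon

Two measured steps change the same aromatic group on the shared core: a number 0.2 percentage points lower from compound 1 to compound 3 (within the scatter) and a number 2 percentage points lower from compound 1 to compound 2 (within the scatter). Both stay within the scatter. Changing this group across three quite different shapes has so far produced no step beyond the scatter in this assay, so the expected step of a number 0.1 percentage points lower from compound 3 to compound 4 (within the scatter) is likewise one of no change beyond the scatter. Compound 4 is therefore estimated at 4%, expected to fall between -5% and 14%.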

Compound 4, a percentage reported as inhibition, at one concentration (the size of the read-out at that concentration, not a potency): 2.79%
For compound 4 the middle estimate is 1.2 percentage points above the measured one; the measured number falls inside the stated range.
By their numbers in this assay, from the lowest: compounds 2, 4, 3 and 1 (each within the scatter of the next).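

In this assay the 2-methoxyphenyl group adds something the earlier groups on this aromatic carbon did not show: an oxygen-bearing group, with 1 hydrogen-bond acceptor where 4-chlorophenyl has 0. Even so, every new step stays within the scatter: a number 1.3 percentage points lower from compound 3 to compound 4 (within the scatter) and a number 0.4 percentage points higher from compound 2 to compound 4 (within the scatter) and also a number 1.5 percentage points lower from compound 1 to compound 4 (within the scatter). This position has now carried four different groups without a step beyond the scatter, and no supporting data are available to explain this result.

All four numbers are small, so the compounds shown cannot tell whether this position has any influence on inhibition at the one concentration tested. Going by these compounds, it also stays open whether a phenyl ring bearing an amine or a carboxylic acid here, or a group other than cyclohexyl on the shared core, would give a step beyond the scatter.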